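The source may hold more compounds than are shown below. What is called first, only, known or untested is meant among the compounds shown, and "the series" means these compounds.

- compound 1 `CC(C)(C)c1cc(NC(=O)Nc2ccc(NC(=O)c3ccc(OC4CCN(C(C)(C)C)CC4)cn3)cc2)no1` gives 22% in an in vivo ADME assay on the whole organism (plasma, strain Sprague-Dawley) for pharmacokinetics, with Rattus norvegicus as the target, read by LC-MS, at a dose of 10 mg/kg by the oral route; on this read-out lower numbers stand for lower oral bioavailability and higher numbers for higher oral bioavailability
- compound 2 `CC(C)(C)c1cc(NC(=O)Nc2ccc(NC(=O)c3ccc(OC4CCNCC4)cn3)cc2)no1` gives 1% in this assay

Going by the values given here, compound 2 holds the lower of these two numbers, and with only two compounds measured, that says little about the wider series. The next compound is compound 3 `CC(C)(C)c1cc(NC(=O)Nc2ccc(NC(=O)c3ccc(OC4CCN(C5CC5)CC4)cn3)cc2)no1` with a single change, cyclopropyl in place of hydrogen on an amine nitrogen in a ring.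

Among the compounds with values here, only one measured step bears on this change. It concerns the same nitrogen, where hydrogen in place of tert-butyl gave a number 21 percentage points lower from compound 1 to compound 2 (beyond the scatter), a modest step beyond the scatter. Compound 3 goes the opposite way, putting a carbon group back on that nitrogen. However, cyclopropyl is not tert-butyl, and no compound with cyclopropyl has yet been measured, so this single step is only a loose guide. In this assay a rise of similar size is therefore expected, and the estimated step is a number 17 percentage points higher from compound 2 to compound 3 (beyond the scatter) in this read-out. For compound 3 the expected value is 18%, with an estimated range from 6% to 35%.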

Compound 3, oral bioavailability: 36%
For compound 3 the middle estimate is 18 percentage points below the measured one, and the stated range ends below it.
By their numbers in this assay, from the lowest: compound 2; then compound 1; then compound 3.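

In this assay, the ring nitrogen of the piperidin-4-yl group can now be compared across three substituents, and placing cyclopropyl on it gives a number 35 percentage points higher from compound 2 to compound 3 (beyond the scatter) in a large step. The earlier pair showed only that removing tert-butyl from this nitrogen lowered the number, whereas the exchange of one carbon group for another here gives a number 14 percentage points higher from compound 1 to compound 3 (beyond the scatter) in a modest step, so the outcome depends on which carbon group is present and not merely on whether the nitrogen carries one. No measurement shown here explains why cyclopropyl and tert-butyl differ in this way.

On these data alone, what happens with other groups on this nitrogen stays open, whether a methyl group, a longer chain such as propyl, or a ring such as cyclobutane or oxetane, so three compounds cannot show whether any trend runs through such groups. It is also unknown whether the order seen in this assay would hold if the same nitrogen substituents were carried on a different core.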